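The compounds below may be only part of what the source reports. "The series", "measured", "known", "first", "only" and "open" are said of these compounds alone.

Measured so far in an ADME assay on Vero cells (Chlorocebus sabaeus) for cytotoxicity, read by MTT assay; on this read-out lower numbers stand for stronger inhibition and higher numbers for weaker inhibition:
- compound 2 `C=CCOc1cc(OC)c(C(=O)/C=C/c2ccc(F)cc2)c(OCC=C)c1`: 13600 nM
- compound 3 `C=CCOc1cc(OC)c(C(=O)/C=C/c2ccccc2Br)c(OCC=C)c1`: 13900 nM
- compound 1 `C=CCOc1cc(OC)c(C(=O)/C=C/C=C/c2ccccc2)c(OCC=C)c1`: "not determined" (no result reported)

Among the measured compounds shown here, compound 2 is one of only two compounds with a number in this assay. Compound 3 sits right alongside it: the step of a 1.0-fold higher number from compound 2 to compound 3 (0.01 log units; within the scatter) is within the scatter, so the two cannot be told apart and neither can be called more or less toxic to the cells than the other. Compound 1 has no result, so it adds nothing to the picture.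

Compound 4 `C=CCOc1cc(OC)c(C(=O)/C=C/c2ccccn2)c(OCC=C)c1` differs from compound 2 at a single spot: pyridin-2-yl in place of 4-fluorophenyl on a double-bonded chain carbon bound to a double-bonded chain carbon. For the measured compounds named here, the one measured step that bears on this is the exchange of 4-fluorophenyl for 2-bromophenyl at the same chain carbon, from compound 2 to compound 3, which left the number essentially unchanged a 1.0-fold higher number from compound 2 to compound 3 (0.01 log units; within the scatter). A ring carrying a nitrogen has not been tried at this spot, so the data give no guide to any shift in either direction, and the expectation defaults to no step beyond the scatter. Compound 4 is therefore estimated to give 14000 nM in this assay, with a range of 7000 nM to 30000 nM. That estimate corresponds to the step of a 1.0-fold higher number from compound 2 to compound 4 (0.01 log units; within the scatter), expected to lie within the scatter.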

Compound 4, half-maximal inhibitory concentration: 2800 nM
For compound 4 the middle estimate is 5.0-fold (0.70 log units) above the measured one, outside the stated range (below it).
By their numbers in this assay, from the lowest: compound 4; then compounds 2 and 3 (each within the scatter of the next).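

In this assay, among the compounds shown here, pyridin-2-yl on this chain carbon is the first exchange to move the number beyond the scatter, in both available comparisons (a 4.9-fold lower number from compound 2 to compound 4 (0.69 log units; beyond the scatter)) and (a 5.0-fold lower number from compound 3 to compound 4 (0.70 log units; beyond the scatter)). The earlier pair suggested that the ring at this spot could change without consequence, but that held only for 4-fluorophenyl and 2-bromophenyl; the pyridin-2-yl ring, with a nitrogen in the ring and a hydrogen-bond acceptor that the 4-fluorophenyl group lacks, shows that cell toxicity in this assay does respond to what sits here. Nothing available explains why the number falls, so the counted difference between these groups remains a description and not a cause.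

Going by these compounds, with a single nitrogen-containing ring in the set, it remains open whether the lower number belongs to pyridin-2-yl specifically or would also appear with pyridin-3-yl, pyridin-4-yl or a pyrimidine ring at the same chain carbon. It is also unknown how a phenyl ring carrying an amine or a carboxylic acid would behave here, so the reach of this change across other groups remains undefined.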